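The source may report more compounds than this note shows. Statements on the series, on what has been measured and on what is new or still open speak of the compounds shown alone.

Measured so far:
compound 1, `Oc1ccc(-c2nc3cc(C(F)(F)F)ccc3[nH]2)cc1`: 17000 nM
compound 2, `C#C[C@@]1(O)[C@H](O)[C@@H](CO)O[C@H]1n1ccc(N)nc1=O`: >= 100000 nM

Within the data shown here, in an ADME assay on MT4 cells (Homo sapiens) for cytotoxicity, read by MTT assay, with a stated time of 96 h (on this read-out lower numbers stand for higher toxicity in this test and higher numbers for lower toxicity in this test), compound 1 gives 17000 nM, the only number among the values shown. For compound 2 the read-out is a limit of the test and not a number, >= 100000 nM; the limit of >= 100000 nM in this assay, at which 1 of the 2 values shown sits, marks where that value sits. Compound 1 therefore stands alone as the single measured figure in this set. Compound 3, `COc1ccc(-c2nc3cc(C(F)(F)F)ccc3[nH]2)cc1`, is not yet measured; it differs from compound 1 by methyl in place of hydrogen on an oxygen on an aromatic ring. Among the measured compounds shown here, no measured step is available to lean on, so compound 3 is expected to move little, with a step of a 1.2-fold higher number from compound 1 to compound 3 (0.07 log units; within the scatter) expected, not beyond the scatter. Compound 3 is estimated at 20000 nM, between 7000 nM and 60000 nM.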

Compound 3, half-maximal cytotoxic concentration: 2000 nM
Beside the measured number, compound 3's estimate is 10-fold (1.00 log units) above it; measured number below the stated range.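

In this assay, among these compounds, the change from hydroxy to methoxy gives an 8.5-fold lower number from compound 1 to compound 3 (0.93 log units; beyond the scatter), the first step that can be read. The oxygen on the aromatic ring is therefore a place where a single added methyl shifts the read-out towards higher toxicity in this test. Nothing shown accounts for this step.

Open, as far as these compounds go, is whether a longer chain such as ethyl on this oxygen, or an amine in place of the hydroxy, moves the number further. Also open, from the compounds shown here alone, is whether changes elsewhere on the shared core matter as much.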